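This account rests on a few compounds, and the source may have more. Where it says the series, first, only, none or still open, it means among the compounds named here.

Of the compounds shown here, three sharing one core have been measured in a functional assay on EOL1 cells (Homo sapiens) for inhibition, read by fluorescence, with a stated time of 72 h; a lower number here means a stronger inhibitor of growth, a higher number a weaker inhibitor of growth. Compound 1 `CC(C)CCn1cnc2c(NCc3cccc(Cl)c3)nc(N[C@H]3CC[C@H](N)CC3)nc21` gives 1330 nM. Compound 2 `CC(C)CCn1cnc2c(Nc3ccc(Cl)cc3)nc(N[C@H]3CC[C@H](N)CC3)nc21` gives 90 nM, and compound 3 `CC(C)CCn1cnc2c(Nc3cccc(O)c3)nc(N[C@H]3CC[C@H](N)CC3)nc21` gives 60 nM. Compound 2 stands apart from compound 1 but not from compound 3: the step of a 15-fold lower number from compound 1 to compound 2 (1.17 log units; beyond the scatter) is large, while the step of a 1.5-fold lower number from compound 2 to compound 3 (0.18 log units; within the scatter) lies within the scatter, so compounds 2 and 3 cannot be told apart on these numbers.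

Compound 4 `CCCCCCn1cnc2c(Nc3ccc(Cl)cc3)nc(N[C@H]3CC[C@H](N)CC3)nc21` has not yet been measured. It differs from compound 2 in one place only: butyl in place of isopropyl on a saturated chain carbon, two bonds along the chain from an aromatic nitrogen. The chain on the aromatic nitrogen is lengthened and straightened, while the rest of the molecule is untouched.

For the measured compounds named here, none of the measured steps touches this chain. The steps of a 15-fold lower number from compound 1 to compound 2 (1.17 log units; beyond the scatter), a 22-fold lower number from compound 1 to compound 3 (1.35 log units; beyond the scatter) and a 1.5-fold lower number from compound 2 to compound 3 (0.18 log units; within the scatter) all change the group on the other nitrogen of the core, so they show how much that part matters but say nothing about the chain. Going by the values given here, with no direct precedent, the expectation for compound 4 in this assay is a step of a 1.3-fold higher number from compound 2 to compound 4 (0.12 log units; within the scatter), that is, no change beyond the scatter in either direction. Compound 4 is therefore expected to give about 120 nM, with a range from 40 nM to 360 nM.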

Compound 4, concentration for 50% growth inhibition: 440 nM
Compound 4: the middle estimate sits 3.7-fold (0.56 log units) below what was measured; the measured number lies above the stated range.
By their numbers in this assay, from the lowest: compounds 3 and 2 (each within the scatter of the next); then compound 4; then compound 1.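

The chain on the aromatic nitrogen of the shared core is not a silent part of the molecule: in this assay, putting hexyl in place of isopentyl (the same difference as butyl in place of isopropyl, cut one bond further out) gives a 4.9-fold higher number from compound 2 to compound 4 (0.69 log units; beyond the scatter) as a modest step. For the compounds shown here, every earlier step changed the group on the other nitrogen, so this is the first sign that growth inhibition also responds to a change on a saturated chain carbon, two bonds along the chain from an aromatic nitrogen, and here the straight, longer chain goes with the weaker inhibitor of growth. No measurement is available that explains this result.

This single step lengthens and straightens the chain together, so the compounds shown cannot say which of the two changes matters. From the compounds shown here alone, a straight pentyl chain or a shorter ethyl chain on that nitrogen would help separate the two, and it also remains open whether hexyl has a similar effect when 3-hydroxyphenyl sits on the other nitrogen.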